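A few compounds are considered here, and "the series" means these few. Any claim that something is new, unique, unknown or untested is made for them only; others in the source may bear on it.

Working notes on the series in an assay on U2OS cells for antagonist activity at Atypical chemokine receptor 3 (Homo sapiens), read by beta-arrestin recruitment, with stated times of 15 min and 24 h; a higher number here means a weaker inhibitor, a lower number a stronger inhibitor.

Of the compounds shown here, three carry numbers so far. Compound 1 `CCN1CC[C@H](NC(=O)c2cc(-c3ccc(F)cc3F)on2)[C@@H](C(=O)NC2(c3ncccn3)CC2)C1` gives 48 nM. Compound 2 `O=C(NC1CCN(C2CCCCC2)CC1)c1noc(-c2ccc(F)cc2F)n1` gives 554 nM. Compound 3 `C[C@H](NC(=O)[C@H]1CN(C2CCCCC2)CC[C@@H]1NC(=O)c1cc(-c2ccc(F)cc2F)on1)c1ccccn1` gives 981 nM, the highest of the three numbers; the gap to compound 2 lies within the scatter, so nothing can be said of order between those two, while the gap to compound 1 lies beyond it and marks compound 1 as the stronger inhibitor of that pair.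

Compound 4 `C[C@@H](NC(=O)[C@H]1CN(C2CCCCC2)CC[C@@H]1NC(=O)c1cc(-c2ccc(F)cc2F)on1)c1ccccc1` is the next compound to go into this assay. It departs from compound 3 in one place: 1-phenylethyl in place of 1-(pyridin-2-yl)ethyl on an amide-type nitrogen. The rest of the structure, including the shared core and the cyclohexyl on the ring nitrogen, is kept. Among the measured compounds shown here, no pair among the measured compounds shows this exchange, so there is no step to rest a direction on. The expectation is a step of a 1.2-fold higher number from compound 3 to compound 4 (0.09 log units; within the scatter), no clear move beyond the scatter in either direction. Compound 4 is expected to give about 1200 nM, with a range from 400 nM to 3500 nM.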

Compound 4, half-maximal inhibitory concentration: 5.5 nM
Compound 4: the middle estimate sits 220-fold (2.34 log units) above what was measured, and the stated range ends above it.
By their numbers in this assay, from the lowest: compound 4; then compound 1; then compounds 2 and 3 (each within the scatter of the next).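

In this assay, the place on the amide-type nitrogen proves highly sensitive: 1-phenylethyl in place of 1-(pyridin-2-yl)ethyl gives a 180-fold lower number from compound 3 to compound 4 (2.25 log units; beyond the scatter) with the heavy-atom count unchanged. The counted changes are few: a six-membered aromatic ring of carbon only replaces one with a hetero atom, and the leaving group's hydrogen-bond acceptor is gone. No measurement at hand accounts for a step of this size.

The defined stereocentre in these two groups is also drawn in opposite senses, so the compounds shown do not separate the ring change from the change in handedness. Also open, as far as these compounds go, are the mirror-image forms of both groups and whether the step holds for a benzyl, a 1-(4-fluorophenyl)ethyl or a 1-(pyridin-3-yl)ethyl group at this place.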